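The source may report more compounds than this note shows. Statements on the series, on what has been measured and on what is new or still open speak of the compounds shown alone.

Measured so far in an ADME assay on J774 cells (Mus musculus) for cytotoxicity; a higher number here means that more compound is needed for the effect, a lower number that less compound is needed:

- compound 1 `CCCCc1cc2c(=O)c(C(C)=O)c[nH]c2cc1OCCOc1ccccc1`: "not determined" (no result reported)
- compound 2 `CCCCc1ccc2[nH]cc(C(=O)OC)c(=O)c2c1`: > 20000 nM, a limit of the assay rather than a number
- compound 3 `CCCCc1cc2c(=O)c(I)c(C)[nH]c2cc1OCCOc1ccccc1`: "not determined" (no result reported)

Compound 1 stands nowhere on this scale: it has no single number in this assay, one further entry among the three is a limit, and one further entry has no number at all. The only mark on the scale comes from compound 2, which sits at the limit of > 20000 nM in this assay, at which 1 of the 3 values shown sits. Going by the values given here, compound 1 and compound 3 carry no result, so no step between measured compounds can be drawn.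

Compound 4 `CCCCc1cc2c(=O)c(Br)c[nH]c2cc1OCCOc1ccccc1` is to be measured next. The change from compound 1 is bromo in place of acetyl on an aromatic carbon.

With no number for compound 1 in this assay, no step to compound 4 can be sized, in either direction, and none beyond the scatter is expected on the evidence shown. Compound 4 is expected to give about 20000 nM, within 5000 nM to 60000 nM, with a fair chance that only a limit is reported.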

Compound 4, half-maximal effective concentration: 8070 nM
Estimate against measurement, compound 4: 2.5-fold (0.39 log units) above; measured number inside the range.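

In this assay, going by these compounds alone, compound 4 gives 8070 nM while compound 1 reads "not determined" (no result reported), so no step between the two can be read. Still open, from the compounds shown here alone, is whether bromo in place of acetyl on this aromatic carbon shifts the value in either direction.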